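Swapping Chloro for Fluoro on the Sulfonyl Ring

The source may report more compounds than this note shows. Statements on the series, on what has been measured and on what is new or still open speak of the compounds shown alone.

Compound 2 `Cc1ccc(S(=O)(=O)Oc2ccccc2/C=C(\C#N)C(=O)Nc2nnc(Cc3ccc(Cl)cc3)s2)cc1` gives 69% in a functional assay on RS4-11 cells (Homo sapiens) for inhibition, read by CCK-8 assay, with a stated time of 48 h, tested at 20 uM; on this read-out higher numbers stand for more inhibition of growth at the one concentration tested and lower numbers for less inhibition of growth. Compound 1 `Cc1ccc(S(=O)(=O)Oc2ccccc2/C=C(\C#N)C(=O)Nc2nnc(Cc3ccc(F)cc3)s2)cc1` gives 72% in this assay and differs from it by fluoro in place of chloro on an aromatic carbon, a step that reads a number 3 percentage points higher from compound 2 to compound 1 (within the scatter). Compound 3 `N#C/C(=C\c1ccccc1OS(=O)(=O)c1ccc(Cl)cc1)C(=O)Nc1nnc(Cc2ccc(Cl)cc2)s1` carries a different core, set apart from compound 2 by chloro in place of methyl on an aromatic carbon; in this assay compound 3 gives 64%, and the step reads a number 5 percentage points lower from compound 2 to compound 3 (within the scatter). Compound 4 `N#C/C(=C\c1ccccc1OS(=O)(=O)c1ccc(F)cc1)C(=O)Nc1nnc(Cc2ccc(Cl)cc2)s1` is not yet measured. It differs from compound 3 by fluoro in place of chloro on an aromatic carbon, the same change already seen between compound 2 and compound 1, here on the ring bearing the sulfonyl rather than the benzyl. Because the earlier step of a number 3 percentage points higher from compound 2 to compound 1 (within the scatter) stayed within the scatter, the step from compound 3 to compound 4 is expected to be a number 2 percentage points higher from compound 3 to compound 4 (within the scatter). Compound 4 is therefore estimated at 66% in this assay, between 56% and 76%.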

Compound 4, percent growth inhibition at one concentration: 64%
The estimate for compound 4 lay 2 percentage points above the measured number, and the stated range covers the measured number.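

In this assay the swap of chloro for fluoro gives no change at the digits printed from compound 3 to compound 4 (within the scatter) and the swap of methyl for fluoro gives a number 5 percentage points lower from compound 2 to compound 4 (within the scatter). The chloro-to-fluoro change reads alike on the two cores: the same change on two cores in this assay, a number 3 percentage points higher (within the scatter) from compound 2 to compound 1 and no change at the digits printed (within the scatter) from compound 3 to compound 4, 3 percentage points apart, within the scatter of two such steps. So in these two pairs the change can be carried from one core to the other with no visible difference in growth inhibition, but this does not show that it would behave the same way on any other core, or at any other concentration.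

The compounds shown leave open how an amine, a carboxylic acid or a longer chain would read in place of the halogen on the ring bearing the sulfonyl. Only halogens and methyl appear at that place here, and every step among them stays within the scatter.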